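Swapping azepan-1-yl on a short-lived amide

A few compounds are considered here, and "the series" means these few. Any claim that something is new, unique, unknown or untested is made for them only; others in the source may bear on it.

In an ADME assay (liver, Mus musculus) for metabolic stability, using microsomes (a lower number here means that the compound disappears faster, a higher number that the compound lasts longer), compound 1 (`CCc1nc2ccc(Cl)cn2c1C(=O)NCc1ccc(-c2ccc(C#N)cc2)cc1`) reports > 1 h as its result, which is a limit of the assay and not a number. Within the data shown here, compound 2 (`CCc1nc2cc(Cl)ccn2c1C(=O)NCc1ccc(N2CCCCCC2)cc1`) gives 0.0317 h as the only actual number so far. Compound 3 (`CCc1nc2cc(Cl)ccn2c1C(=O)NCc1ccc(-n2cc3c(c2)CCCC3)cc1`) keeps the core of compound 2 and differs by one change: a group of 9 heavy atoms (8 carbon, 1 nitrogen; one five-membered aromatic ring with 1 hetero atom, one six-membered non-aromatic ring of carbon only) in place of a group of 7 heavy atoms (6 carbon, 1 nitrogen; one seven-membered non-aromatic ring with 1 hetero atom), on an aromatic carbon on an aromatic carbon of a six-membered aromatic ring of carbon only, para to a large group. Among the measured compounds shown here, no measured pair shows this change, so the expectation rests on little. With compound 2 at 0.0317 h as the starting point, a moderate rise in half-life is expected in this assay and no fall of any size beyond the scatter. The expected step is a 2.8-fold higher number from compound 2 to compound 3 (0.45 log units; beyond the scatter) as a rough estimate. Compound 3 is estimated at 0.09 h with an expected range of 0.03 h to 0.4 h in this read-out.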

Compound 3, half-life: 1.04 h
Compound 3: middle estimate off by 12-fold (1.06 log units), on the low side; the whole stated range lies below it.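

The swap at this position gives a 33-fold higher number from compound 2 to compound 3 (1.52 log units; beyond the scatter) in this assay and shows that the group on the aromatic carbon, para to a large group, can by itself move the half-life by a large step while the rest of compound 2 stays unchanged. Neither group adds a hydrogen-bond donor or a net charge, and both carry one hydrogen-bond acceptor, so these counts do not separate the two compounds. Compound 3 at 1.04 h lies close to the top of what this read-out reports, so any further rise in this series may be hard to put a number on: the limit of > 1 h in this assay, at which 1 of the 3 values shown sits.

This single pair does not tell whether the five-membered aromatic ring or the six-membered carbon ring carries the step. A plain pyrrol-1-yl or a morpholin-4-yl at this position would help to separate the two.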